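The source may report more compounds than this note shows. Statements on the series, on what has been measured and on what is new or still open speak of the compounds shown alone.

Measured compounds:
Compound 1 `COc1cc(C)cc(-c2nn(CC#N)cc2-c2ccc(-c3cccc(C(C)=O)c3)nc2)c1` — in a functional assay on U-251 cells (Homo sapiens) for inhibition, read by sulforhodamine B assay, with a stated time of 48 h (a lower number here means that less compound is tolerated, a higher number that more compound is tolerated), compound 1 reaches only the limit of the assay, > 100000 nM.
Compound 2 `Cc1cc(O)cc(-c2nn(CC#N)cc2-c2ccnc(-c3ccc(Oc4ccccc4)cc3)c2)c1` — in this assay compound 2 gives 5560 nM.

Going by the values given here, compound 2 thus holds the only number in this set. For compound 1 there is only (the limit of > 100000 nM in this assay, at which 1 of the 2 values shown sits). Compound 3 `Cc1cc(O)cc(-c2nn(CC#N)cc2-c2ccnc(-c3ccc(N(C)C)cc3)c2)c1` has not yet been measured. It differs from compound 2 by dimethylamino in place of phenoxy on an aromatic carbon. Among the compounds with values here, no measured pair frames this change, so the expected step of a 1.4-fold lower number from compound 2 to compound 3 (0.14 log units; within the scatter) is modest, toward less compound being tolerated, and could fall within the scatter. Compound 3 is therefore expected at 4000 nM, between 1200 nM and 15000 nM.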

Compound 3, concentration lethal to 50% of the cells: 61300 nM
Estimate against measurement, compound 3: 15-fold (1.19 log units) below, outside the stated range (above it).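

In this assay, putting dimethylamino in place of phenoxy on this aromatic carbon, para to a large group, gives an 11-fold higher number from compound 2 to compound 3 (1.04 log units; beyond the scatter), so more compound is tolerated. This first single-place comparison shows that the group on this carbon matters, though one pair cannot separate the loss of the ring from the change of the linking atom. Compound 1 remains a limit, not a number: the limit of > 100000 nM in this assay, at which 1 of the 3 values shown sits.

Going by these compounds, whether a morpholine or a benzyloxy group on this carbon would give a number closer to compound 2 or to compound 3 remains open.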